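The compounds below may be only part of what the source reports. "The series", "measured", "known", "first", "only" and "open" are said of these compounds alone.

Working notes on the series. In a functional assay on M21 cells (Homo sapiens) for antiproliferative activity, read by sulforhodamine B assay, with a stated time of 48 h (a higher number here means a weaker inhibitor of growth, a lower number a stronger inhibitor of growth), compound 3 (`NS(=O)(=O)NCCC1CCN(c2cc(-c3ccc(Cl)cc3)ncn2)CC1`) gives 45200 nM, the highest of the two numbers recorded there; the nearest is compound 1 (`CCOC(=O)c1ccc(-c2cc(N3CCC(CNS(N)(=O)=O)CC3)ncn2)cc1`), which gives 5000 nM. Compound 2 (`NS(=O)(=O)NCCC1CCN(c2cc(-c3ccccc3)ncn2)CC1`) returns only a limit in this assay, > 100000 nM. Among the measured compounds shown here, the one measured step, an at least 2.2-fold lower number from compound 2 to compound 3 (0.34 log units; beyond the scatter), rests on that limit (the limit of > 100000 nM in this assay, at which 1 of the 3 values shown sits) and so gives only a floor for its size.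

Compound 4 (`CCOC(=O)c1ccc(-c2cc(N3CCC(CCNS(N)(=O)=O)CC3)ncn2)cc1`) is not yet measured. The change from compound 3 is ethoxycarbonyl in place of chloro on an aromatic carbon, on an aromatic carbon of a six-membered aromatic ring of carbon only. For the measured compounds named here, no measured step covers chloro against ethoxycarbonyl directly. Compound 1 carries the same ethoxycarbonyl group with a shorter chain and sits well under compound 3, so compound 4 is expected to move in that direction, with a step of about a 5.7-fold lower number from compound 3 to compound 4 (0.75 log units; beyond the scatter) in this assay. The estimate for compound 4 is therefore 8000 nM, with a range from 2500 nM to 30000 nM.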

Compound 4, concentration for 50% growth inhibition: 9000 nM
Beside the measured number, compound 4's estimate is 1.1-fold (0.05 log units) below it; the measured number falls inside the stated range.
By their numbers in this assay, from the lowest: compounds 1 and 4 (each within the scatter of the next); then compound 3. At a limit, above all of these: compound 2.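

On the aromatic carbon para to a large group, ethoxycarbonyl can now be read directly against chloro in this assay: a 5.0-fold lower number from compound 3 to compound 4 (0.70 log units; beyond the scatter). Against hydrogen the reading is an at least 11-fold lower number from compound 2 to compound 4 (1.04 log units; beyond the scatter), which gives only a floor for the size of the step, since compound 2 stands at a limit: the limit of > 100000 nM in this assay, at which 1 of the 4 values shown sits.

With ethoxycarbonyl held in place, the difference in chain between the two compounds lies within the scatter: a 1.8-fold higher number from compound 1 to compound 4 (0.26 log units; within the scatter).

Open, as far as these compounds go, is whether a carboxylic acid or a primary amide on this aromatic carbon would read as ethoxycarbonyl does. Also open, from the compounds shown here alone, is whether a chain longer than that of compound 4 would stay within the scatter of compound 4.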